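The source may report more compounds than this note shows. Statements on the series, on what has been measured and on what is new or still open speak of the compounds shown alone.

Measured compounds in a physicochemical assay for lipophilicity, using the shake flask method, at pH 7.4; on this read-out lower numbers stand for lower lipophilicity and higher numbers for higher lipophilicity:

compound 1 `O=C(O)CCNC(=O)c1ccc(C(Oc2ccc(-n3cc(C(F)(F)F)cn3)cc2)C2CCCC2)cc1` — in this assay compound 1 gives 3.3
compound 2 `CCCC(Oc1ccc(-n2cc(F)cn2)cc1)c1ccc(C(=O)NCCC(=O)O)cc1` — in this assay compound 2 gives 2

Compound 2 holds the lower of the two numbers; its nearest neighbour, compound 1, stands higher by a gap beyond the scatter. For the measured compounds named here, the two compounds differ in more than one place, so no single step between them is counted.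

Compound 3 `CCCC(Oc1ccc(-n2cc(C#N)cn2)cc1)c1ccc(C(=O)NCCC(=O)O)cc1` has not yet been measured. It differs from compound 2 in one place: cyano in place of fluoro on an aromatic carbon. The group leaves and enters on an aromatic carbon of a five-membered aromatic ring with 2 nitrogen. Going by the values given here, no measured pair shows this change, so the expectation rests on the change itself. A step downward is expected, near the edge of the scatter or somewhat beyond it, as a number 0.50 log units lower from compound 2 to compound 3 (beyond the scatter). Compound 3 is estimated at 1.5, expected between 1 and 2.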

Compound 3, distribution coefficient: 1.2
Beside the measured number, compound 3's estimate is 0.30 log units above it; the range from low to high includes it.
By their numbers in this assay, from the lowest: compound 3; then compound 2; then compound 1.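

Going from 4-fluoro-1H-pyrazol-1-yl to 4-cyano-1H-pyrazol-1-yl gives, in this assay, a number 0.80 log units lower from compound 2 to compound 3 (beyond the scatter), the first step in the series that can be assigned to one place. With the rest of the molecule unchanged, this position alone can move the read-out beyond the scatter, whereas the gap between compound 1 and compound 2 spans more than one place and assigns nothing to it. No measured evidence bears on the origin of this step.

From the compounds shown here alone, the change rests on a single pair, so it remains open whether the same change would give a similar step on the core of compound 1. Also open, going by these compounds, is how a chloro, a methoxy or an amine on the same aromatic carbon would read in this assay against fluoro and cyano.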